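A Chloro Added to the Trifluoromethylphenyl Urea

The source may hold more compounds than are shown below. What is called first, only, known or untested is meant among the compounds shown, and "the series" means these compounds.

Compound 1 `O=C(Nc1cccc(-n2cc(-c3ccncc3)c(-c3ccc(Cl)c(O)c3)n2)c1)Nc1cccc(C(F)(F)F)c1` is the starting point. In a functional assay on MCF7 cells (Homo sapiens) for inhibition, read by sulforhodamine B assay, with a stated time of 48 h (a higher number here means a weaker inhibitor of growth, a lower number a stronger inhibitor of growth), compound 1 gives only a limit, > 32500 nM, and this is the limit of > 32500 nM in this assay, at which 1 of the 3 values shown sits. Compound 2 `COc1cc(-c2nn(-c3cccc(NC(=O)Nc4cccc(C(F)(F)F)c4)c3)cc2-c2ccncc2)ccc1Cl` gives 7720 nM in this assay, and compound 3 `O=C(Nc1cccc(-n2cc(-c3ccncc3)c(-c3ccc(Cl)c(O)c3)n2)c1)Nc1cc(C(F)(F)F)cc(C(F)(F)F)c1` gives 5790 nM. Both changes from compound 1 lower the number beyond the scatter: an at least 4.2-fold lower number from compound 1 to compound 2 (0.62 log units; beyond the scatter) and an at least 5.6-fold lower number from compound 1 to compound 3 (0.74 log units; beyond the scatter). Compound 4 `O=C(Nc1cccc(-n2cc(-c3ccncc3)c(-c3ccc(Cl)c(O)c3)n2)c1)Nc1ccc(Cl)c(C(F)(F)F)c1` differs from compound 1 by chloro in place of hydrogen on an aromatic carbon. Because an at least 5.6-fold lower number from compound 1 to compound 3 (0.74 log units; beyond the scatter) was seen on the same ring, a drop of similar size in this assay is expected, namely an at least 5.0-fold lower number from compound 1 to compound 4 (0.69 log units; beyond the scatter). Compound 4 is therefore estimated at 6500 nM, within a range of 2000 nM to 20000 nM.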

Compound 4, concentration for total growth inhibition: > 32500 nM
Compound 4: a limit, no number; the forecaster's own chance of this, stated with the estimate: 20%; at least 5.0-fold (0.69 log units) between middle value and limit.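

For the compounds shown here, compound 1 and compound 4 each give only a limit, not a number, in this assay, so no step between them can be read: the limit of > 32500 nM in this assay, at which 2 of the 4 values shown sit. The compounds shown leave open whether chloro in place of hydrogen on this ring changes growth inhibition at all.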